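A Sulfonyl Group Replaces the Pyridinyl Amide of Compound 1

This account rests on a few compounds, and the source may have more. Where it says the series, first, only, none or still open, it means among the compounds named here.

Compound 1 `CNc1nc(NCc2ccc(NC(=O)c3ccncc3)cc2)c2ccccc2n1` was tested in a functional assay on SW480 cells (Homo sapiens) for inhibition, read by luminescence and resazurin assay, with a stated time of 3 days; a lower number here means a stronger inhibitor, a higher number a weaker inhibitor. In this assay compound 1 gives only a limit, > 20000 nM, so no exact number is known for it (the limit of > 20000 nM in this assay, at which 1 of the 3 values shown sits). Two single changes to compound 1 have been measured. Compound 2 `CN(C)c1nc(NCc2ccc(NC(=O)c3ccncc3)cc2)c2ccccc2n1` gives 11000 nM in this assay, and the step of an at least 1.8-fold lower number from compound 1 to compound 2 (0.25 log units; that floor lies within the scatter) touches the core side of the molecule. Compound 3 `CNc1nc(NCc2ccc(C(=O)Nc3ccc(F)cc3)cc2)c2ccccc2n1` gives 4100 nM in this assay, and the step of an at least 4.8-fold lower number from compound 1 to compound 3 (0.68 log units; beyond the scatter) changes the same region of the molecule that is altered here. Compound 4 `CNc1nc(NCc2ccc(NS(=O)(=O)c3ccc(C)cc3)cc2)c2ccccc2n1` has not yet been measured; it differs from compound 1 by (4-methylphenyl)sulfonyl in place of (pyridin-4-yl)carbonyl on a nitrogen on an aromatic ring. Going by the values given here, only the step to compound 3 bears directly on this change, and it showed that altering this group can lower the number beyond the scatter. A lower number is therefore expected for compound 4 in this assay, though a limit remains possible. The estimate for compound 4 is 9000 nM, between 2500 nM and 35000 nM. This expected step is an at least 2.2-fold lower number from compound 1 to compound 4 (0.34 log units; beyond the scatter).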

Compound 4, half-maximal inhibitory concentration: 4900 nM
Estimate against measurement, compound 4: 1.8-fold (0.26 log units) above, within the range that was stated.
By their numbers in this assay, from the lowest: compounds 3 and 4 (each within the scatter of the next); then compound 2. At a limit, above all of these: compound 1.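

On the nitrogen on an aromatic ring, (4-methylphenyl)sulfonyl in place of (pyridin-4-yl)carbonyl gives an at least 4.0-fold lower number from compound 1 to compound 4 (0.61 log units; beyond the scatter) in this assay, so a lower number is reached with this nitrogen kept and with a six-membered aromatic ring of carbon only entering. Compound 3 at 4100 nM and compound 4 at 4900 nM lie within the scatter of each other, which means two different replacements in this region reach the same level. The size of the step remains a floor, resting on a limit for compound 1: the limit of > 20000 nM in this assay, at which 1 of the 4 values shown sits.

The compounds shown leave open whether the lower number follows the sulfonyl or the carbon-only ring, as both enter in this one step. As far as these compounds go, a pyridin-4-yl or a plain methyl on the sulfonyl would separate the two, and a carboxylic acid or an amine in place of the ring's methyl remains untested here.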